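A Longer Amine Tail and Cytotoxicity in Liver Cells

A few compounds are considered here, and "the series" means these few. Any claim that something is new, unique, unknown or untested is made for them only; others in the source may bear on it.

Measured so far in an ADME assay on Huh-7 cells (Homo sapiens) for cytotoxicity; a higher number here means that more compound is tolerated, a lower number that less compound is tolerated:
compound 1, `Cc1ccccc1-c1nn(-c2ccc(F)cc2F)cc1CNCCN(C)C` — compound 1 gives > 20000 nM, which is a limit of the assay.
compound 2, `CN1CCN(CCNCc2cn(-c3ccc(F)cc3F)nc2-c2ccc(N(C)C)cc2)CC1` — compound 2 gives > 20000 nM, which is also a limit.

Compound 1 therefore stands at the limit of > 20000 nM in this assay, at which 2 of the 2 values shown sit; no numerical value separates it from compound 2, and neither compound reveals a measurable half-maximal cytotoxic concentration within the tested range.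

Compound 3, `CCN(CC)CCCNCc1cn(-c2ccc(F)cc2F)nc1-c1ccccc1C`, has not yet been measured. It differs from compound 1 in one place: (diethylamino)methyl in place of dimethylamino on a saturated chain carbon, two bonds along the chain from an amine nitrogen. The shared core of compound 1 and the two-bond distance along the chain from the amine nitrogen are retained; only the terminal amine and the chain length change.

Within the data shown here, with both measured compounds sitting at the limit, no step between measured compounds is available to guide expectation. The step from compound 1 to compound 3 is expected to be a step that the limit leaves unreadable from compound 1 to compound 3, that is, nothing beyond the scatter, with compound 3 most likely returning another limit. For compound 3 the estimated value in this assay is 25000 nM, with a range from 10000 nM to 60000 nM.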

Compound 3, half-maximal cytotoxic concentration: > 20000 nM
Compound 3: no number, only a limit; the forecaster's own chance of this, stated with the estimate: 75%; the middle value lies beyond the limit too.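

In this assay, among these compounds, compound 3 gives > 20000 nM, which is a limit of the assay, and since compound 1 also sits at a limit, no step from compound 1 to compound 3 can be read. All three compounds stand together: the limit of > 20000 nM in this assay, at which 3 of the 3 values shown sit.

The compounds shown leave open at what concentration any of them becomes cytotoxic in this assay, and whether (diethylamino)methyl in place of dimethylamino changes that concentration at all.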